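Swapping the Benzyl Substituent: From Compound 3 to Compound 4

The source may report more compounds than this note shows. Statements on the series, on what has been measured and on what is new or still open speak of the compounds shown alone.

Of the compounds shown here, three built on one shared core have been measured in a functional assay on MCF7 cells (Homo sapiens) for cytotoxicity, read by MTT assay, with a stated time of 48 h; on this read-out higher numbers stand for weaker inhibition and lower numbers for stronger inhibition. Compound 1 `CCN(CC)c1ccc2cc(C(=O)c3ccc(N4CCN(C(=O)CN5CCNCC5)CC4)cc3)oc2c1` carries an unsubstituted amine nitrogen in its terminal ring and gives 5340 nM. Compound 2 `CCN(CC)c1ccc2cc(C(=O)c3ccc(N4CCN(C(=O)CN5CCN(C(=O)/C=C/c6ccccc6)CC5)CC4)cc3)oc2c1` places a (2-phenylethenyl)carbonyl on that nitrogen and gives 13400 nM; the step of a 2.5-fold higher number from compound 1 to compound 2 (0.40 log units; beyond the scatter) lies beyond the scatter. Compound 3 `CCN(CC)c1ccc2cc(C(=O)c3ccc(N4CCN(C(=O)CN5CCN(Cc6ccc(/C=C/C(=O)OC)cc6)CC5)CC4)cc3)oc2c1` instead carries a 4-(2-(methoxycarbonyl)ethenyl)phenyl on a saturated chain carbon bound to that ring nitrogen and gives 8730 nM. Among the three numbers compound 3 stands second highest, yet its value lies within the scatter of both compound 2 and compound 1, so no order among these three can be drawn from it.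

Compound 4 `CCN(CC)c1ccc2cc(C(=O)c3ccc(N4CCN(C(=O)CN5CCN(Cc6ccc(F)c(F)c6)CC5)CC4)cc3)oc2c1` differs from compound 3 by 3,4-difluorophenyl in place of 4-(2-(methoxycarbonyl)ethenyl)phenyl on a saturated chain carbon bound to an amine nitrogen in a ring. Going by the values given here, no measured step alters this group, so none bears directly on it; the only measured step, a 2.5-fold higher number from compound 1 to compound 2 (0.40 log units; beyond the scatter), concerns the ring nitrogen itself rather than the group on the chain carbon. Since all three measured values sit in a narrow band, the expected step is a 1.2-fold lower number from compound 3 to compound 4 (0.10 log units; within the scatter), not beyond the scatter. Compound 4 is therefore estimated at 7000 nM, with a range from 3000 nM to 16000 nM.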

Compound 4, half-maximal inhibitory concentration: 9220 nM
Compound 4: the middle estimate sits 1.3-fold (0.12 log units) below what was measured, within the range that was stated.
By their numbers in this assay, from the lowest: compounds 1, 3, 4 and 2 (each within the scatter of the next, the first and the last beyond it).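

In this assay, the change at this position gives a 1.1-fold higher number from compound 3 to compound 4 (0.02 log units; within the scatter) even though a group of 12 heavy atoms with 2 hydrogen-bond acceptors gives way to one of 8 heavy atoms with 0 acceptors, so this large swap of the group on the saturated chain carbon leaves no readable mark on the number. The 3,4-difluorobenzyl group also cannot be told apart from the two other groups on the ring nitrogen: the comparison with the (2-phenylethenyl)carbonyl group gives a 1.5-fold lower number from compound 2 to compound 4 (0.16 log units; within the scatter) and the comparison with plain hydrogen gives a 1.7-fold higher number from compound 1 to compound 4 (0.24 log units; within the scatter) while those two compounds themselves stand further apart. No measurement of any property of these groups is available to account for this result.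

On these data alone, it remains open whether an amine or a carboxylic acid on the aromatic ring, or a longer chain joining that ring to the ring nitrogen, would shift the number beyond the usual scatter. As far as these compounds go, the shared core is the same in all four compounds, so the effect of changing it also remains unknown.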